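Benzylamino to 2-hydroxyphenyl on a carbonyl carbon

The source may hold more compounds than are shown below. What is called first, only, known or untested is meant among the compounds shown, and "the series" means these compounds.

- compound 1 `Cc1ccc(S(=O)(=O)N[C@@H](CC(=O)NC(C)(C)C)C(=O)NCCNC(=O)c2c(O)cccc2F)cc1` gives > 11100 nM as a limit
- compound 2 `Cc1ccc(S(=O)(=O)N[C@@H](CC(=O)NC(C)(C)C)C(=O)NCCNC(=O)NCc2ccccc2)cc1` gives > 11100 nM as a limit
- compound 3 `Cc1ccc(S(=O)(=O)N[C@@H](CC(=O)NC(C)(C)C)C(=O)NCCNC(=O)c2ccccc2O)cc1` is not yet measured

In an ADME assay on Karpas-1106P cells (Homo sapiens) for cytotoxicity (a lower number here means that less compound is needed, a higher number that more compound is needed for the effect), compound 2 stands at > 11100 nM as a limit of the assay and not a number. Going by the values given here, the series so far shows the limit of > 11100 nM in this assay, at which 2 of the 2 values shown sit, and no readable number. Going to compound 3 puts 2-hydroxyphenyl in place of benzylamino on a carbonyl carbon in the shared core. Among the compounds with values here, the only measured step bearing on this is a step that the two limits leave unreadable from compound 1 to compound 2 and it exchanged 2-fluoro-6-hydroxyphenyl for benzylamino at that same place. Within the data shown here, compound 1, the one measured compound with a hydroxyphenyl-type group there, gives > 11100 nM as a limit. On that basis no step beyond the scatter is expected, and the expected step is a step that the limit leaves unreadable from compound 2 to compound 3 in this assay as a working figure. A further limit is the likeliest report. For compound 3 the estimated value is 15000 nM with an expected range from 6000 nM to 40000 nM in this assay as a rough guide.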

Compound 3, half-maximal effective concentration: > 11100 nM
Compound 3: no number, only a limit (the forecaster's own chance of this, stated with the estimate: 85%); the middle value does not contradict the limit.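

In this assay compound 3 gives > 11100 nM as a limit and not a number. Going by these compounds alone, no step among compound 1, compound 2 and compound 3 can be read: the limit of > 11100 nM in this assay, at which 3 of the 3 values shown sit.
On these data alone, whether the groups on this carbonyl carbon differ at all in this assay stays open.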